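Where compound 4 may fall after compound 3

This account rests on a few compounds, and the source may have more. Where it says the series, first, only, none or still open, it means among the compounds named here.

Compound 1 (`Fc1ccc2c(c1CNc1ncc(Oc3ccccc3)c3nncn13)CCO2`): 8000 nM
Compound 2 (`CC1(C)CC(=O)N(c2cnc(NCc3c(F)ccc4c3CCO4)n3cnnc23)C1`): 57000 nM
Compound 3 (`O=C(Nc1cnc(NCc2c(F)ccc3c2CCO3)n2cnnc12)c1cccnc1`): 12000 nM

In a physicochemical assay for solubility, read by LC-MS, in phosphate buffer, with a stated time of 24 h, at pH 7.4 (a higher number here means a more soluble compound, a lower number a less soluble compound), compound 3 stands second highest of the three at 12000 nM. It lies within the scatter of compound 1 and clearly under compound 2. Compound 4 (`C[C@H]1CC(=O)N(c2cnc(NCc3c(F)ccc4c3CCO4)n3cnnc23)C1`) differs from compound 3 at one place: 4-methyl-2-oxopyrrolidin-1-yl replaces ((pyridin-3-yl)carbonyl)amino on an aromatic carbon, para to a large group (4-methyl-2-oxopyrrolidin-1-yl in place of ((pyridin-3-yl)carbonyl)amino on an aromatic carbon). The most relevant measurement is a 4.8-fold lower number from compound 2 to compound 3 (0.68 log units; beyond the scatter), in which the group compound 4 gives up replaced 4,4-dimethyl-2-oxopyrrolidin-1-yl. The same dimethyl group also gave a 7.1-fold higher number from compound 1 to compound 2 (0.85 log units; beyond the scatter), whereas the pyridine-bearing group gave only a 1.5-fold higher number from compound 1 to compound 3 (0.18 log units; within the scatter). Among the compounds with values here, no measured compound carries the 4-methyl group itself, so this reading is indirect. A modest rise is expected, estimated as a 4.2-fold higher number from compound 3 to compound 4 (0.62 log units; beyond the scatter). For compound 4 the estimated value is 50000 nM, with an expected range from 20000 nM to 120000 nM.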

Compound 4, solubility: 200000 nM
Estimate against measurement, compound 4: 4.0-fold (0.60 log units) below; measured number above the stated range.
By their numbers in this assay, from the lowest: compounds 1 and 3 (each within the scatter of the next); then compound 2; then compound 4.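

In this assay, this place on the shared core, para to a large group, proves able to reach well beyond what compound 2 had suggested: 4-methyl-2-oxopyrrolidin-1-yl gives a 17-fold higher number from compound 3 to compound 4 (1.22 log units; beyond the scatter) and a 25-fold higher number from compound 1 to compound 4 (1.40 log units; beyond the scatter), both large steps. The two 2-oxopyrrolidin-1-yl groups also prove not to be interchangeable, since going from the 4,4-dimethyl to the 4-methyl group gives a 3.5-fold higher number from compound 2 to compound 4 (0.55 log units; beyond the scatter), so the substitution on that ring matters and not only the presence of the ring. No measurement at hand accounts for these rises.

On these data alone, it remains open whether the unsubstituted 2-oxopyrrolidin-1-yl group or the opposite stereoisomer of the 4-methyl group would give a similar number. As far as these compounds go, it is equally open whether a six-membered 2-oxopiperidin-1-yl group or a simple amine at this place would hold such a value.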